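A few compounds are considered here, and "the series" means these few. Any claim that something is new, unique, unknown or untested is made for them only; others in the source may bear on it.

In a functional assay on the whole organism (strain Sprague-Dawley) for inhibition, with Rattus norvegicus as the target, with a stated time of 10 min (a higher number here means that more compound is needed for the effect, a lower number that less compound is needed), compound 1 (`CCOc1ccc(Cl)cc1-c1ncc(C(=O)O)c(=O)[nH]1`) gives 0.5 mg/kg. Compound 2 (`CCOc1ccc(S(N)(=O)=O)cc1-c1ncc(C(=O)O)c(=O)[nH]1`) gives > 50 mg/kg, and this is a limit of the assay, not a number. Its true position is therefore unknown, and the limit of > 50 mg/kg in this assay, at which 1 of the 2 values shown sits, is all that can be said of it. Among the compounds with values here, the only measured step is sulfamoyl in place of chloro on an aromatic carbon, which gave an at least 100-fold higher number from compound 1 to compound 2 (2.00 log units; beyond the scatter).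

Compound 3 (`CCOc1ccc(S(=O)(=O)N(CC)CC)cc1-c1ncc(C(=O)O)c(=O)[nH]1`) has diethylamino in place of amino on a sulfonyl sulfur. Within the data shown here, no measured step changes anything on that sulfur, so the evidence is indirect. Compound 3 keeps the sulfonyl group introduced in the step to compound 2, which cost an at least 100-fold higher number from compound 1 to compound 2 (2.00 log units; beyond the scatter), so a return to the level of compound 1 is not expected. A modest move in this assay toward a lower number is the likeliest outcome, and another limit reading is quite possible. The expected change is an at least 2.0-fold lower number from compound 2 to compound 3 (0.30 log units; that floor lies within the scatter). For compound 3 the estimated value is 25 mg/kg, with an expected range from 4 mg/kg to 100 mg/kg.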

Compound 3, dose for 50% inhibition: 40 mg/kg
Compound 3: the middle estimate sits 1.6-fold (0.20 log units) below what was measured; measured number inside the range.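

Compound 2 gave only a limit of the assay, not a number: the limit of > 50 mg/kg in this assay, at which 1 of the 3 values shown sits.

Compound 3 gives a true reading in this assay, so a sulfonyl group at this position now has a measured point. Diethylamino on the sulfonyl sulfur gives an at least 1.2-fold lower number from compound 2 to compound 3 (0.09 log units; that floor lies within the scatter), and this floor alone does not establish a real gain. Compared with the chloro compound, the whole replacement gives an 80-fold higher number from compound 1 to compound 3 (1.90 log units; beyond the scatter), so this sulfonyl group carrying diethylamino stays far from the chloro level.

Going by these compounds, how strongly the reading depends on the group attached to the sulfur stays open, and one pair that includes a limit cannot settle that. Dimethylamino, a piperidine ring or a plain methyl group on the same sulfur would show whether the size and shape of that group matter, and whether any sulfonyl group at this position can come close to the level of the chloro compound.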